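From Cyano to Acetyl on a Short Side Chain

The source may report more compounds than this note shows. Statements on the series, on what has been measured and on what is new or still open speak of the compounds shown alone.

In a functional assay (trachea) with Cavia porcellus as the target (a higher number here means that more compound is needed for the effect, a lower number that less compound is needed), compound 1 (`CCCn1c(=O)n(CCC(N)=O)c(=O)c2[nH]cnc21`) gives 13100 nM as its value. Compound 2 (`CCCn1c(=O)n(C)c(=O)c2c1ncn2CC#N`) gives 35300 nM as its value, the higher of the two numbers and beyond the usual scatter, so it needs more compound for the effect. Compound 3 (`CCCn1c(=O)n(C)c(=O)c2c1ncn2CC(C)=O`), not yet measured, differs from compound 2 by carrying acetyl in place of cyano on a saturated chain carbon bound to an aromatic nitrogen. Within the data shown here, no measured pair shows this change, so only a modest shift can be expected. In this assay the expected step is a 1.6-fold lower number from compound 2 to compound 3 (0.21 log units; within the scatter) and points slightly lower, not beyond the scatter. Compound 3 is estimated at 22000 nM with 8000 nM to 60000 nM as the expected range.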

Compound 3, half-maximal effective concentration: 1900 nM
Estimate against measurement, compound 3: 12-fold (1.06 log units) above; measured number outside the range, below it.
By their numbers in this assay, from the lowest: compound 3; then compound 1; then compound 2.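

In this assay there is a 19-fold lower number from compound 2 to compound 3 (1.27 log units; beyond the scatter) with acetyl in place of cyano on a saturated chain carbon bound to an aromatic nitrogen. This shows that a small change in the group at this place can strongly alter how much compound is needed, which compounds 1 and 2 could not show, as they differ in more than one place. No available evidence explains this step. The compounds shown leave open how an amine, a carboxylic acid or a longer chain would behave at this place. They also leave open whether the same change would give a similar step on another core.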